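From phenyl to benzyl in a series at its limit

A few compounds are considered here, and "the series" means these few. Any claim that something is new, unique, unknown or untested is made for them only; others in the source may bear on it.

In an ADME assay on RAW264.7 cells (Mus musculus) for cytotoxicity, read by MTT assay, with a stated time of 24 h, in the absence of a further agent (on this read-out higher numbers stand for weaker inhibition and lower numbers for stronger inhibition), compound 1 (`Cc1noc(CC2OC(=O)c3ccccc32)n1`) gives > 40000 nM, which is a limit of the assay and not a number. Compound 2 (`O=C1OC(Cc2nc(-c3ccccc3)no2)c2ccccc21`) gives > 40000 nM, again only a limit. Compound 2 therefore has no number of its own and stands with compound 1 at the limit of > 40000 nM in this assay, at which 2 of the 2 values shown sit.

The next structure is compound 3 (`O=C1OC(Cc2nc(Cc3ccccc3)no2)c2ccccc21`), which carries benzyl in place of phenyl on an aromatic carbon. The change sits on the same carbon of the five-membered aromatic ring that carried methyl in compound 1 and phenyl in compound 2.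

Among the compounds with values here, the only measured step bearing on it is a step that the two limits leave unreadable from compound 1 to compound 2. That step has no readable size, so it offers no magnitude to carry forward, and the two limits give no direction either. No change beyond the scatter is therefore expected in this assay, and a further limit is the most likely report. The expected step is a step that the limit leaves unreadable from compound 2 to compound 3. For compound 3 the estimate is 50000 nM, with an expected range of 20000 nM to 120000 nM.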

Compound 3, half-maximal inhibitory concentration: > 40000 nM
Compound 3: only a limit was reported; the forecaster's own chance of this, stated with the estimate: 85%; the middle value does not contradict the limit.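

In this assay compound 3 gives > 40000 nM, again a limit and not a number. No step among compound 1, compound 2 and compound 3 can be read: the limit of > 40000 nM in this assay, at which 3 of the 3 values shown sit.

The compounds shown leave open whether methyl, phenyl and benzyl on this aromatic carbon differ at all in this assay.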